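Amide nitrogen substituent and cytotoxicity: compound 2 to compound 3

This account rests on a few compounds, and the source may have more. Where it says the series, first, only, none or still open, it means among the compounds named here.

Compound 1 `C=CC1=C(C(=O)NCc2ccccc2)C(c2ccc(OC)cc2)OC1`. In a functional assay on HeLa cells (Homo sapiens) for cytotoxicity, read by MTT assay, with a stated time of 24 h (a higher number here means a weaker inhibitor, a lower number a stronger inhibitor), compound 1 gives > 100000 nM, which is a limit of the assay rather than a number.
Compound 2 `C=CC1=C(C(=O)NCCC)C(c2ccc(OC)cc2)OC1`. In this assay compound 2 gives 14000 nM.

For the measured compounds named here, compound 2 holds the only numeric value in this assay; the other value is a limit. Going by the values given here, the single measured step is an at least 7.1-fold lower number from compound 1 to compound 2 (0.85 log units; beyond the scatter); its size is open-ended because of the limit of > 100000 nM in this assay, at which 1 of the 2 values shown sits. Compound 3 `C=CC1=C(C(=O)Nc2ccccc2OC)C(c2ccc(OC)cc2)OC1` differs from compound 2 by 2-methoxyphenyl in place of propyl on an amide-type nitrogen. The measured step bears on this only loosely: it shows that the amide substituent holding a six-membered aromatic ring gave the weaker inhibitor, and compound 3 again carries such a ring, now on the amide-type nitrogen itself. A move back toward weaker inhibition is therefore expected for compound 3, as a step of a 4.3-fold higher number from compound 2 to compound 3 (0.63 log units; beyond the scatter), with a fair chance that only a limit is reported. Compound 3 is expected to give 60000 nM, within 15000 nM to 150000 nM.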

Compound 3, half-maximal inhibitory concentration: > 100000 nM
Compound 3 gave a limit, no number (the forecaster's own chance of this, stated with the estimate: 45%); at least 1.6-fold (0.22 log units) between middle value and limit.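

In this assay, 2-methoxyphenyl in place of propyl on the amide-type nitrogen gives an at least 7.1-fold higher number from compound 2 to compound 3 (0.85 log units; beyond the scatter). Compound 3 gives > 100000 nM, which is a limit of the assay and not a number. Compound 1, with benzyl, and compound 3, with 2-methoxyphenyl, both end at a limit, while compound 2, with propyl, gives a number, so this outcome also occurs with the six-membered aromatic ring bound directly to the amide-type nitrogen rather than held on a saturated chain.

Going by these compounds, the step between compound 1 and compound 3 cannot be read, and the true size of the step from compound 2 stays open: the limit of > 100000 nM in this assay, at which 2 of the 3 values shown sit. It also remains open how a butyl chain, a cyclohexyl ring or an unsubstituted phenyl on the amide-type nitrogen would compare with propyl and 2-methoxyphenyl.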